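This account rests on a few compounds, and the source may have more. Where it says the series, first, only, none or still open, it means among the compounds named here.

Measured compounds in a functional assay on MDA-MB-231 cells (Homo sapiens) for antiproliferative activity, read by CCK-8 assay, with a stated time of 72 h; on this read-out lower numbers stand for stronger inhibition and higher numbers for weaker inhibition:
compound 1 `COc1ccc(C(=O)Nc2cccc(-c3oc4cc(-c5ccc(F)cc5)ccc4c(=O)c3O)c2)cc1` gives 16500 nM
compound 2 `O=C(Nc1cccc(-c2oc3cc(-c4ccc(F)cc4)ccc3c(=O)c2O)c1)c1cccc(F)c1` gives 2510 nM
compound 3 `N#Cc1ccc(C(=O)Nc2cccc(-c3oc4cc(-c5ccc(F)cc5)ccc4c(=O)c3O)c2)cc1` gives 11600 nM

Compound 3 holds the second highest number of the three; its gap to compound 1 is within the scatter (a 1.4-fold lower number from compound 1 to compound 3 (0.15 log units; within the scatter)), while a 4.6-fold higher number from compound 2 to compound 3 (0.66 log units; beyond the scatter) lies beyond it. Compound 4 `O=C(Nc1cccc(-c2oc3cc(-c4ccc(F)cc4)ccc3c(=O)c2O)c1)c1ccc(-c2ccccc2)cc1` differs from compound 3 by phenyl in place of cyano on an aromatic carbon. For the measured compounds named here, no measured step introduces a phenyl; the only step at the same position, from methoxy to cyano, is a 1.4-fold lower number from compound 1 to compound 3 (0.15 log units; within the scatter), within the scatter. Steps beyond the scatter here come from a change of substitution pattern, not from swapping a group at this position. A small step is therefore expected in this assay, estimated as a 1.5-fold lower number from compound 3 to compound 4 (0.16 log units; within the scatter), and compound 4 is expected at 8000 nM (range 2500 nM to 25000 nM).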

Compound 4, half-maximal inhibitory concentration: 63200 nM
For compound 4 the middle estimate is 7.9-fold (0.90 log units) below the measured one, and the stated range ends below it.
By their numbers in this assay, from the lowest: compound 2; then compounds 3 and 1 (each within the scatter of the next); then compound 4.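

In this assay this position proves sensitive to the group it carries: a 5.4-fold higher number from compound 3 to compound 4 (0.74 log units; beyond the scatter), and a 3.8-fold higher number from compound 1 to compound 4 (0.58 log units; beyond the scatter), so unlike the swap of methoxy for cyano, these replacements by phenyl lie beyond the scatter. The 4-phenylphenyl amide also extends the span of the series, with a 25-fold higher number from compound 2 to compound 4 (1.40 log units; beyond the scatter). No measurement on hand explains the rise. Going by these compounds, whether it is specific to an added aromatic ring remains open, as does the outcome with an amine, a carboxylic acid or a longer chain at this position.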